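The source may report more compounds than this note shows. Statements on the series, on what has been measured and on what is new or still open speak of the compounds shown alone.

Values so far in a functional assay on PC-3 cells (Homo sapiens), read by wound healing assay, with a stated time of 24 h; a higher number here means a weaker inhibitor, a lower number a stronger inhibitor 
- compound 1 `CC(C)CCOc1ccc(/C=C2\NC(=O)NC2=O)cc1` with 21700000 nM; 46100 nM (2 entries) 
- compound 2 `Cc1nc[nH]c1/C=C1\NC(=O)NC1=O` with 10500000 nM 

Compound 2 rests on a single number in this assay (10500000 nM), and a further entry for it gives no single number. That number falls inside the span of compound 1, whose entries (the several entries of compound 1 in this assay, 21700000 nM; 46100 nM (2 entries)) lie far apart, so one reading in this measure carries limited weight.

Compound 3 `O=C1NC(=O)/C(=C/c2cnc[nH]2)N1` keeps the rest of compound 2 and changes it in one place (hydrogen in place of methyl on an aromatic carbon), with hydrogen in place of methyl on an aromatic carbon. Among the compounds with values here, no pair of measured compounds shows what such a change does in this assay and the data offer no ground for a direction. The expectation is therefore no step beyond the scatter. The estimated change (a 1.1-fold lower number from compound 2 to compound 3 (0.02 log units; within the scatter)) stays within that scatter. For compound 3 the estimated value is 10000000 nM with an expected range from 500000 nM to 50000000 nM in this measure, and the wide span reflects the spread seen for compound 1.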

Compound 3, half-maximal inhibitory concentration: 18500000 nM
Compound 3: middle estimate off by 1.9-fold (0.27 log units), on the low side, and the stated range covers the measured number.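

In this assay, hydrogen in place of methyl on an aromatic carbon of the five-membered aromatic ring gives a 1.8-fold higher number from compound 2 to compound 3 (0.25 log units; within the scatter) and is the only step between measured compounds shown here. The change removes one heavy atom, a carbon, from the position next to the ring nitrogen, and the two compounds stay within the scatter of each other, so the data show no measurable role for this methyl in this assay. This reading rests on a single number for each compound, and it carries limited weight because entries for the same compound can lie far apart: the several entries of compound 1 in this assay, 21700000 nM; 46100 nM (2 entries).

From the compounds shown here alone, whether a larger group on this aromatic carbon, such as a longer chain, an amine or a carboxylic acid, would move the number beyond the scatter remains open. Within the data shown here, this one pair is also the only place where the change can be read, so whether the same exchange would behave alike on another core is unresolved.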